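The compounds below may be only part of what the source reports. "The series", "measured", "known", "first", "only" and "open" are said of these compounds alone.

Compound 1 `COc1cc(O)c(C(=O)/C=C/c2ccc(F)cc2)c(OC)c1`: > 20000 nM
Compound 2 `COc1cccc(/C=C/C(=O)c2c(OC)cc(OC)cc2OC)c1`: > 20000 nM
Compound 3 `COc1cc(OC)c(C(=O)/C=C/c2ccc(F)cc2)c(OC)c1`: > 20000 nM

In an ADME assay on cells (Fibroblast, Homo sapiens) for cytotoxicity, with a stated time of 48 h (a lower number here means a stronger inhibitor, a higher number a weaker inhibitor), compound 1 gives > 20000 nM, which is a limit of the assay and not a number. Compound 2 gives > 20000 nM, likewise a limit. Compound 3 gives > 20000 nM, again a limit. All three values sit at the limit of > 20000 nM in this assay, at which 3 of the 3 values shown sit, so none of the steps among them can be read.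

Compound 3 and compound 1 differ by hydrogen in place of methyl on an oxygen on an aromatic ring. The step that the two limits leave unreadable from compound 3 to compound 1 shows only that both ends lie at the limit. The two cores of compound 2 and compound 3 differ by 3-methoxyphenyl in place of 4-fluorophenyl on a double-bonded chain carbon bound to a double-bonded chain carbon, and here too the step that the two limits leave unreadable from compound 2 to compound 3 is unreadable.

Compound 4 `COc1cccc(/C=C/C(=O)c2c(O)cc(OC)cc2OC)c1` has not yet been measured in this assay. It differs from compound 2 by hydrogen in place of methyl on an oxygen on an aromatic ring, the same change as that from compound 3 to compound 1, made at the same place on the core of compound 2. Since every measured value in this series sits at the limit of > 20000 nM in this assay, at which 3 of the 3 values shown sit, the step from compound 2 to compound 4 is expected to be a step that the limit leaves unreadable from compound 2 to compound 4, meaning that compound 4 is expected to stay beyond the limit as well. Compound 4 is estimated at 40000 nM, with the expectation lying between 15000 nM and 150000 nM.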

Compound 4, half-maximal inhibitory concentration: > 20000 nM
Compound 4: only a limit was reported; the forecaster's own chance of this, stated with the estimate: 80%; the middle value does not contradict the limit.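

In this assay compound 4 gives > 20000 nM and this is a limit, not a number. No new step can be read between compound 2 and compound 4, because both ends stand at the same limit: the limit of > 20000 nM in this assay, at which 4 of the 4 values shown sit.

The compounds shown leave open how far compound 1, compound 2, compound 3 and compound 4 lie beyond that limit, and so whether methoxy to hydroxy changes the value at all.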